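Replacing a thioether link with a methylpiperazine in a cytotoxicity series

The source may hold more compounds than are shown below. What is called first, only, known or untested is meant among the compounds shown, and "the series" means these compounds.

Going by the values given here, compound 2 `Cc1nnc(SCC(=O)Nc2ccc(-c3nc(-c4ccccc4)c(-c4ccccc4)n3C)cc2)s1` stands highest of the two numbers measured so far in a functional assay on HT-29 cells (Homo sapiens) for cytotoxicity, read by MTT assay, with a stated time of 24 h, tested at 32 ug/mL (a higher number here means a stronger effect of the compound at the concentration tested, a lower number a weaker effect), giving 87.1%. Among the compounds with values here, its nearest neighbour, compound 1 `Cn1c(-c2ccc(NC(=O)CSc3nc4cc(Cl)ccc4o3)cc2)nc(-c2ccccc2)c1-c1ccccc1`, gives 61.9% in this assay, and the single step between the two, a number 25.2 percentage points higher from compound 1 to compound 2 (beyond the scatter), came from one exchange: 5-methyl-1,3,4-thiadiazol-2-yl in place of 5-chloro-1,3-benzoxazol-2-yl on a sulfur.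

Compound 3 `CN1CCN(CC(=O)Nc2ccc(-c3nc(-c4ccccc4)c(-c4ccccc4)n3C)cc2)CC1` has not yet been measured. It differs from compound 2 in one place: 4-methylpiperazin-1-yl in place of (5-methyl-1,3,4-thiadiazol-2-yl)sulfanyl on a saturated chain carbon bound to a carbonyl carbon. Within the data shown here, no measured step makes this exact exchange; the only step available, from compound 1 to compound 2, kept the sulfur and changed only the ring attached to it, yet it shows that alterations at this end of the molecule can move the read-out by a modest amount. Among the measured compounds shown here, with the sulfur-linked ring gone and a saturated ring in its place, the outcome has no direct precedent here, so a step in either direction is possible and a wide range is warranted.

The estimate for compound 3 in this assay is 55%, between 25% and 85%, which would mean an expected step of a number 32.1 percentage points lower from compound 2 to compound 3 (beyond the scatter).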

Compound 3, a percentage reported as activity, at one concentration (the size of the read-out at that concentration, not a potency): 49.1%
Compound 3: middle estimate off by 5.9 percentage points, on the high side, within the range that was stated.
By their numbers in this assay, from the lowest: compound 3; then compound 1; then compound 2.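

In this assay, the earlier step changed only the ring held on the sulfur, whereas this change removes the sulfur link itself and places a saturated ring on a saturated chain carbon bound to a carbonyl carbon, giving a number 38 percentage points lower from compound 2 to compound 3 (beyond the scatter) and also a number 12.8 percentage points lower from compound 1 to compound 3 (beyond the scatter). Thus 4-methylpiperazin-1-yl ranks below both sulfur-linked groups at this position, even though it has the same 7 heavy atoms as (5-methyl-1,3,4-thiadiazol-2-yl)sulfanyl, yet compound 3 still gives 49.1%, so a sulfur-linked aromatic ring is not needed for a measurable read-out. No measurement here explains why the read-out falls with this exchange.

Because the sulfur, the aromatic ring and the point of attachment all change in one exchange, these compounds cannot show which of those differences accounts for the drop. A morpholin-4-yl or dimethylamino group on the same carbon, a longer chain carrying the 4-methylpiperazin-1-yl ring, or a simple phenylsulfanyl group would help to separate those contributions.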